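Benzyl to benzoyl on the piperidine nitrogen

The source may report more compounds than this note shows. Statements on the series, on what has been measured and on what is new or still open speak of the compounds shown alone.

The series shares one core and varies the group on the saturated chain carbon bound to an amine nitrogen in a ring. In a functional assay for antagonist activity at C-X-C chemokine receptor type 3 (Homo sapiens) (on this read-out lower numbers stand for stronger inhibition and higher numbers for weaker inhibition), compound 1 `CNC(=O)c1cnc(N2CCN(C3CCN(Cc4ccc(C)cc4)CC3)[C@@H](C)C2)c(Cl)c1` gives 87 nM. Compound 2 `CNC(=O)c1cnc(N2CCN(C3CCN(Cc4ccc(Cl)cc4F)CC3)[C@@H](C)C2)c(Cl)c1` gives 18 nM in this assay, and compound 3 `CNC(=O)c1cnc(N2CCN(C3CCN(Cc4ccc(Cl)cc4Cl)CC3)[C@@H](C)C2)c(Cl)c1` gives 17 nM. The steps of a 4.8-fold lower number from compound 1 to compound 2 (0.68 log units; beyond the scatter) and a 5.1-fold lower number from compound 1 to compound 3 (0.71 log units; beyond the scatter) are both modest and beyond the scatter, whereas a 1.1-fold lower number from compound 2 to compound 3 (0.02 log units; within the scatter) lies within the scatter, so compound 3 holds the lowest number of the three but cannot be set apart from compound 2. Compound 4 `CNC(=O)c1cnc(N2CCN(C3CCN(C(=O)c4ccc(Cl)cc4)CC3)[C@@H](C)C2)c(Cl)c1` brings a different kind of change: (4-chlorophenyl)carbonyl in place of 2,4-dichlorobenzyl on an amine nitrogen in a ring. For the measured compounds named here, no measured step covers the exchange of the benzyl linkage for a carbonyl; the steps from compound 1 only show that ring substituents shift this assay modestly. The expectation for compound 4 is therefore a somewhat weaker number than for compound 3, estimated as a 3.5-fold higher number from compound 3 to compound 4 (0.55 log units; beyond the scatter), with wide uncertainty. Compound 4 is expected to give about 60 nM in this assay, within 15 nM to 300 nM.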

Compound 4, half-maximal inhibitory concentration: 210 nM
Estimate against measurement, compound 4: 3.5-fold (0.54 log units) below; measured number inside the range.
By their numbers in this assay, from the lowest: compounds 3 and 2 (each within the scatter of the next); then compound 1; then compound 4.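

At this amine nitrogen in a ring, (4-chlorophenyl)carbonyl moves the number in this assay much further than any change among the benzyl groups, with a 12-fold higher number from compound 3 to compound 4 (1.09 log units; beyond the scatter) and a 12-fold higher number from compound 2 to compound 4 (1.07 log units; beyond the scatter), both large. The number also rises against the 4-methylbenzyl group, with a 2.4-fold higher number from compound 1 to compound 4 (0.38 log units; beyond the scatter), so compound 4 is the weakest of the four and none of the benzyl groups falls behind it. No measured evidence on any property bears on this loss.

Each of these steps changes the linkage and the ring substituents together. The data do not separate the change in linkage from the change in ring substituents. A 4-chlorobenzyl group and a 2,4-dichlorobenzoyl group on the same nitrogen would separate the two changes, and a sulfonyl linkage would show whether the loss extends beyond the carbonyl.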